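The compounds below may be only part of what the source reports. "The series", "measured", "known", "first", "only" and "open" are said of these compounds alone.

Among the measured compounds shown here, compound 2 `O=C(N1CCCCC1COc1ccc(F)cc1)n1ncc(C(O)(c2ccc(F)cc2)c2ccc(F)cc2)n1` is one of two compounds measured in an assay on isolated protein for inhibition of Monoacylglycerol lipase ABHD6 (Homo sapiens), read by fluorescence (on this read-out higher numbers stand for weaker inhibition and lower numbers for stronger inhibition), where compound 2 gives 200 nM. Its only companion, compound 1 `COc1ccc(CC2CCCCN2C(=O)n2ncc(C(O)(c3ccc(F)cc3)c3ccc(F)cc3)n2)cc1`, gives 251 nM in this assay, and the two numbers lie within the scatter of each other, so neither can be called the stronger. Compound 3 `COc1cccc(CC2CCCCN2C(=O)n2ncc(C(O)(c3ccc(F)cc3)c3ccc(F)cc3)n2)c1` has not yet been measured. Relative to compound 2 it carries 3-methoxyphenyl in place of 4-fluorophenoxy on a saturated chain carbon bound to a saturated ring carbon. For the measured compounds named here, the one measured step that bears on this change is a 1.3-fold lower number from compound 1 to compound 2 (0.10 log units; within the scatter), which swapped a methoxyphenyl group for the 4-fluorophenoxy group at the same place without a shift beyond the scatter. Since compound 3 returns to a methoxyphenyl group, only with the methoxy on the 3-position, compound 3 is expected to show a 1.5-fold higher number from compound 2 to compound 3 (0.18 log units; within the scatter) in this assay, a step not expected to exceed the scatter. Compound 3 is therefore estimated at 300 nM, with a plausible range from 120 nM to 750 nM.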

Compound 3, half-maximal inhibitory concentration: 158 nM
Compound 3: middle estimate off by 1.9-fold (0.28 log units), on the high side; measured number inside the range.
By their numbers in this assay, from the lowest: compounds 3, 2 and 1 (each within the scatter of the next).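

In this assay the change to 3-methoxyphenyl from 4-fluorophenoxy gives a 1.3-fold lower number from compound 2 to compound 3 (0.10 log units; within the scatter) and the change from 4-methoxyphenyl gives a 1.6-fold lower number from compound 1 to compound 3 (0.20 log units; within the scatter) as its step. Among the compounds shown here, on a saturated chain carbon bound to a saturated ring carbon, the three groups carried by compound 1, compound 2 and compound 3 therefore cannot be told apart in this read-out, and the placing of the methoxy group on the ring makes no difference beyond the scatter, which the single earlier step could not show. No measurement offered here accounts for this flat result.

As far as these compounds go, all three groups hold a six-membered aromatic ring of carbon only, so the reach of this position remains open. From the compounds shown here alone, whether a basic amine, a carboxylic acid or a longer chain in this place would move the number beyond the scatter is unknown.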